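The source may hold more compounds than are shown below. What is called first, only, known or untested is meant among the compounds shown, and "the series" means these compounds.

In a functional assay on B16 cells (Mus musculus) for antiproliferative activity, read by MTT assay, with a stated time of 24 h (on this read-out higher numbers stand for weaker inhibition and lower numbers for stronger inhibition), compound 1 `COc1cc(OC)c(-c2coc3cc(OCc4ccccc4C(F)(F)F)ccc3c2=O)cc1OC` gives 8550 nM and compound 2 `COc1cc(OC)c(-c2coc3cc(OCc4cccc(Cl)c4)ccc3c2=O)cc1OC` gives 2280 nM, the lower of the two numbers. Compound 3 `COc1cc(OC)c(-c2coc3cc(OCc4ccc(C(F)(F)F)cc4)ccc3c2=O)cc1OC` is still unmeasured and differs from compound 2 thus: 4-(trifluoromethyl)phenyl in place of 3-chlorophenyl on a saturated chain carbon bound to an oxygen on an aromatic ring. Among the measured compounds shown here, one measured step bears on this, with 3-chlorophenyl replacing 2-(trifluoromethyl)phenyl: a 3.8-fold lower number from compound 1 to compound 2 (0.57 log units; beyond the scatter), modest and beyond the scatter. With a trifluoromethyl-bearing group returning, though under another name than in compound 1, part of that step is expected to reverse in this assay, on this single step alone. The expected step is a 1.8-fold higher number from compound 2 to compound 3 (0.24 log units; within the scatter). For compound 3 the estimate is 4000 nM, with an expected range of 1500 nM to 11000 nM.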

Compound 3, half-maximal inhibitory concentration: 5400 nM
Beside the measured number, compound 3's estimate is 1.4-fold (0.13 log units) below it; low and high end bracket the measured number.
By their numbers in this assay, from the lowest: compound 2; then compounds 3 and 1 (each within the scatter of the next).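

In this assay a trifluoromethyl group at the 4-position does not match the 3-chlorophenyl of compound 2, with a 2.4-fold higher number from compound 2 to compound 3 (0.37 log units; beyond the scatter) as the step. Within the trifluoromethyl pair, a 1.6-fold lower number from compound 1 to compound 3 (0.20 log units; within the scatter) leaves 2-(trifluoromethyl)phenyl and 4-(trifluoromethyl)phenyl indistinguishable on this read-out, so the place of that group on the phenyl ring shows no effect here. No measurement at hand explains these differences. Still open, on these data alone, is whether chlorine itself or its place on the ring carries the step. Also open, as far as these compounds go, is how an amine or a carboxylic acid on that ring, or a longer chain leading to it, would read.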